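The compounds below may be only part of what the source reports. "The series", "measured", "known", "first", "only" and "open" are said of these compounds alone.

Measured so far:
- compound 1 `Cc1ccsc1-c1cc(-c2ccco2)cc(-c2ccccc2Cl)n1`: 14200 nM
- compound 2 `Cc1ccccc1-c1cc(-c2ccoc2)cc(-c2ccc(Cl)s2)n1`: 1430 nM

In a functional assay on MCF7 cells (Homo sapiens) for cytotoxicity, read by ELISA, with a stated time of 4 days (on this read-out higher numbers stand for weaker inhibition and lower numbers for stronger inhibition), compound 2 gives 1430 nM, the lower of the two numbers and so the stronger inhibition. Compound 1 gives 14200 nM, a gap beyond the usual scatter. Within the data shown here, no measured pair differs in one place only, so no single change has a measured size yet.

The next compound is compound 3 `Clc1ccc(-c2cc(-c3ccoc3)cc(-c3ccccn3)n2)s1`, with pyridin-2-yl in place of 2-methylphenyl on an aromatic carbon. The 5-chlorothiophen-2-yl and furan-3-yl groups stay as they are in compound 2.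

Among the measured compounds shown here, with no measured step as a guide, the expectation starts from compound 2 at 1430 nM and allows for a wide margin. A small move towards weaker inhibition in this assay is expected, and it may not clear the scatter. The expected change is a 1.7-fold higher number from compound 2 to compound 3 (0.24 log units; within the scatter). For compound 3 the estimated value is 2500 nM, with an expected range of 700 nM to 9000 nM.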

Compound 3, half-maximal inhibitory concentration: 3360 nM
Compound 3: the middle estimate sits 1.3-fold (0.13 log units) below what was measured; low and high end bracket the measured number.
By their numbers in this assay, from the lowest: compound 2; then compound 3; then compound 1.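

The swap of 2-methylphenyl for pyridin-2-yl gives the series its first measured single change: in this assay there is a 2.3-fold higher number from compound 2 to compound 3 (0.37 log units; beyond the scatter), a modest move towards weaker inhibition. At this position, on an aromatic carbon next to the ring nitrogen, inhibition therefore responds to the group placed there, although the response is small, and the 5-chlorothiophen-2-yl and furan-3-yl groups stay constant across the pair. The change removes the methyl group and adds a ring nitrogen with a hydrogen-bond acceptor at the same time, so this one step cannot assign its size to either feature, and nothing measured here gives a reason for it.

Still open, as far as these compounds go, is how the step divides between the loss of the methyl group and the gain of the ring nitrogen, a question that plain phenyl at this position would help to settle. Also open, from the compounds shown here alone, is how inhibition in this cell assay responds to a group of a different kind at this position, such as an amine, a carboxylic acid or a longer alkyl chain.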